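Methoxy added to the aryl group of compound 2

The source may report more compounds than this note shows. Statements on the series, on what has been measured and on what is new or still open speak of the compounds shown alone.

Measured so far in a functional assay on cells (Cancer cell lines, Homo sapiens) for cytotoxicity, read by sulforhodamine B assay, with a stated time of 48 h; a higher number here means a weaker inhibitor of growth, a lower number a stronger inhibitor of growth:
compound 1 `O=C1N=C(N2N=C(c3ccccc3)CC2c2ccccc2O)S/C1=C1/C(=O)Nc2ccccc21` gives 2090 nM
compound 2 `COc1ccc(C2CC(c3ccccc3)=NN2C2=NC(=O)/C(=C3\C(=O)Nc4ccccc43)S2)cc1` gives 2020 nM
compound 3 `COc1ccc(C2CC(c3ccccc3)=NN2C2=NC(=O)/C(=C3\C(=O)Nc4ccc(Br)cc43)S2)cc1` gives 200 nM

Compound 2 sits second highest of the three numbers; compound 1 is closest, with a 1.0-fold lower number from compound 1 to compound 2 (0.01 log units; within the scatter), and compound 3 is furthest, with a 10-fold lower number from compound 2 to compound 3 (1.00 log units; beyond the scatter).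

Compound 4 `COc1ccc(C2=NN(C3=NC(=O)/C(=C4\C(=O)Nc5ccccc54)S3)C(c3ccc(OC)cc3)C2)cc1` differs from compound 2 by methoxy in place of hydrogen on an aromatic carbon. Neither measured step touches this spot. Going by the values given here, the step from compound 1 to compound 2 swaps the aryl group on the saturated ring carbon and stays within the scatter, which is the nearest precedent for changing an aryl substituent. The step from compound 2 to compound 3 concerns a bromo on the other part of the core and says nothing about a methoxy here. Among the compounds with values here, with no directly relevant precedent, the expected step is none beyond the scatter, and compound 4 is estimated at 2000 nM, with a range of 700 nM to 6000 nM, meaning a 1.0-fold lower number from compound 2 to compound 4 (0.00 log units; within the scatter).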

Compound 4, concentration for 50% growth inhibition: 81500 nM
For compound 4 the middle estimate is 41-fold (1.61 log units) below the measured one, outside the stated range (above it).
By their numbers in this assay, from the lowest: compound 3; then compounds 2 and 1 (each within the scatter of the next); then compound 4.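

In this assay, going by these compounds alone, going from phenyl to 4-methoxyphenyl gives the first step towards a weaker inhibitor of growth (a 40-fold higher number from compound 2 to compound 4 (1.61 log units; beyond the scatter)), so this position is far from indifferent to substitution. A 4-methoxyphenyl group on the saturated ring carbon, in place of 2-hydroxyphenyl, stays within the scatter (a 1.0-fold lower number from compound 1 to compound 2 (0.01 log units; within the scatter)), so that result does not carry over to the aryl group changed here. No data at hand account for the size of this step.

From the compounds shown here alone, whether the loss belongs to methoxy itself or to any group at this spot remains open, and a fluoro, hydroxy or amine group here would begin to separate the two. Also open, going by these compounds, is whether the bromo of compound 3 would give a similar step on a core carrying this second methoxy.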